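Removing the trifluoromethyl from the dichloroanilino series

The compounds below may be only part of what the source reports. "The series", "measured", "known", "first", "only" and "open" are said of these compounds alone.

Compound 3 `FC(F)(F)c1cccc(Nc2ncnc3sc(Nc4c(Cl)cccc4Cl)nc23)c1` gives 206 nM in a functional assay on HEK293 cells for antagonist activity at transient receptor potential cation channel subfamily V member 1 (Homo sapiens), read by calcium flux (on this read-out higher numbers stand for weaker inhibition and lower numbers for stronger inhibition), the highest number among the three measured compounds. Compound 1 `FC(F)(F)c1ccc(Nc2ncnc3sc(Nc4c(Cl)cccc4Cl)nc23)cc1` gives 12 nM and compound 2 `FC(F)(F)c1ccc(Nc2ncnc3sc(Nc4ccccc4Cl)nc23)cc1` gives 64 nM. Within the data shown here, compound 1 and compound 3 carry the same groups, with the trifluoromethyl sitting on a different ring carbon, and their two values differ widely; no single-change step connects them.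

Compound 4 `Clc1cccc(Cl)c1Nc1nc2c(Nc3ccccc3)ncnc2s1` differs from compound 3 by hydrogen in place of trifluoromethyl on an aromatic carbon. Among the measured compounds shown here, no measured step alters the trifluoromethyl itself. For the measured compounds named here, the only measured step, a 5.3-fold higher number from compound 1 to compound 2 (0.73 log units; beyond the scatter), concerns the other aryl ring, so it bears on this change only by showing that losing a substituent has so far raised the number. With the trifluoromethyl gone entirely, a rise beyond the scatter is expected, of uncertain size given that compound 3 already stands highest.

Compound 4 is therefore estimated at 700 nM in this assay, with a range from 200 nM to 3000 nM, which means an expected step of a 3.4-fold higher number from compound 3 to compound 4 (0.53 log units; beyond the scatter).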

Compound 4, half-maximal inhibitory concentration: 176 nM
Compound 4: the middle estimate sits 4.0-fold (0.60 log units) above what was measured; measured number below the stated range.
By their numbers in this assay, from the lowest: compound 1; then compound 2; then compounds 4 and 3 (each within the scatter of the next).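

In this assay, hydrogen can stand in for the trifluoromethyl meta to a large group with no change beyond the scatter: the step is a 1.2-fold lower number from compound 3 to compound 4 (0.07 log units; within the scatter), so losing a substituent does not raise the number everywhere in this series. The same replacement read from the other placement of the trifluoromethyl gives a 15-fold higher number from compound 1 to compound 4 (1.17 log units; beyond the scatter), which ties the low number of compound 1 to where the group sits, not merely to its presence. No measurement on hand accounts for this difference.

Still open, on these data alone, is whether a nitrile, a methoxy group or an amine on this ring carbon would read any differently from hydrogen. Also open, as far as these compounds go, is whether removing a chloro from compound 4 would raise the number as it did from compound 1 to compound 2.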